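Phenyl to Dimethylphenyl on the Amide Carbonyl

This account rests on a few compounds, and the source may have more. Where it says the series, first, only, none or still open, it means among the compounds named here.

compound 1 `O=C(NCN1CCC(c2cccc[n+]2[O-])CC1)c1ccccc1`: 63%
compound 2 `Cc1cc(NC(=O)CN2CCC(c3cccc[n+]3[O-])CC2)ccc1F`: 75%

Going by the values given here, in a functional assay on HEK293 cells for agonist activity at D(4) dopamine receptor (Homo sapiens), read by FLIPR (a higher number here means a larger maximal response, a lower number a smaller maximal response), compound 1 gives 63%, the lower of the two numbers known so far. Compound 2 gives 75%, a gap beyond the usual scatter. Compound 3 `Cc1ccc(C(=O)NCN2CCC(c3cccc[n+]3[O-])CC2)cc1C` differs from compound 1 in one place: 3,4-dimethylphenyl in place of phenyl on a carbonyl carbon. Among the compounds with values here, no pair of measured compounds shows this change, so the direction rests on nothing more than the two numbers at hand. For compound 3 a small upward step is expected, a number 5 percentage points higher from compound 1 to compound 3 (within the scatter), probably not beyond the scatter. Compound 3 is therefore estimated at 68%, with a range from 50% to 86%.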

Compound 3, largest response reached (reported as efficacy), in percent of the reference or control that the assay uses: 65%
Beside the measured number, compound 3's estimate is 3 percentage points above it; the range from low to high includes it.
By their numbers in this assay, from the lowest: compounds 1, 3 and 2 (each within the scatter of the next, the first and the last beyond it).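

Compound 3 and compound 1 form the only pair shown that differs in one place, and so give the only direct reading of this position. In this assay, 3,4-dimethylphenyl in place of phenyl on a carbonyl carbon gives a number 2 percentage points higher from compound 1 to compound 3 (within the scatter), so the maximal response does not separate these two groups. No other measurement shown bears on this result.

As far as these compounds go, it remains open whether a carboxylic acid or an amine carried on the phenyl ring would move the response beyond the scatter. Whether the same swap behaves alike on another core is also unknown.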